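This account rests on a few compounds, and the source may have more. Where it says the series, first, only, none or still open, it means among the compounds named here.

Measured compounds:
- Compound 1 `Cc1ccc(C2=NN(c3nc(-c4ccc(Br)cc4)cs3)C(c3ccc4c(c3)OCCO4)C2)cc1` gives 1590 nM in a functional assay on MCF7 cells (Homo sapiens) for antiproliferative activity, read by MTT assay, with a stated time of 48 h; on this read-out lower numbers stand for stronger inhibition and higher numbers for weaker inhibition.
- Compound 2 `COc1ccc(-c2csc(N3N=C(c4ccc(Cl)cc4)CC3c3ccc4c(c3)OCCO4)n2)cc1` gives 3030 nM in this assay.
- Compound 3 `COc1ccc(-c2csc(N3N=C(c4ccc(Br)cc4)CC3c3ccc4c(c3)OCCO4)n2)cc1` gives 870 nM in this assay.

Compound 3 has the lowest number of the three, but its gap to compound 1 lies within the scatter, so the two cannot be ranked; only compound 2 stands clearly apart from it. The unmeasured compound 4 `COc1ccc(-c2csc(N3N=C(c4ccc(C)cc4)CC3c3ccc4c(c3)OCCO4)n2)cc1` differs from compound 3 in one place: methyl in place of bromo on an aromatic carbon.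

Among the measured compounds shown here, only one measured step touches this position: a 3.5-fold lower number from compound 2 to compound 3 (0.54 log units; beyond the scatter). That step swaps one halogen for another, not a halogen for a methyl, so it bears on the position but not directly on the new group. Compound 1 carries a methyl at the same position, yet it also differs elsewhere, and its number and that of compound 3 lie within the scatter of each other. Taken together, a small rise in the number is expected for compound 4, with wide uncertainty: a 1.7-fold higher number from compound 3 to compound 4 (0.24 log units; within the scatter). The estimate for compound 4 in this assay is 1500 nM, with a range from 600 nM to 4000 nM.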

Compound 4, half-maximal inhibitory concentration: 2680 nM
For compound 4 the middle estimate is 1.8-fold (0.25 log units) below the measured one; measured number inside the range.
By their numbers in this assay, from the lowest: compounds 3, 1, 4 and 2 (each within the scatter of the next, the first and the last beyond it).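

In this assay, a 3.1-fold higher number from compound 3 to compound 4 (0.49 log units; beyond the scatter) shows that methyl does not match bromo at this position, so the change from 4-bromophenyl to 4-methylphenyl has a real cost. Methyl and chloro, by contrast, cannot be told apart, as a 1.1-fold lower number from compound 2 to compound 4 (0.05 log units; within the scatter) stays within the scatter, so among these three groups in this series only bromo stands apart. On the other aryl ring, with the methyl kept, a 1.7-fold higher number from compound 1 to compound 4 (0.23 log units; within the scatter) is also within the scatter, so methoxy in place of bromo there shows no clear effect. Nothing available here explains why bromo stands apart at this position. The compounds shown leave open how a fluoro group, an amine or a longer alkyl chain would compare at this position.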